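The source may report more compounds than this note shows. Statements on the series, on what has been measured and on what is new or still open speak of the compounds shown alone.

Measured so far in a functional assay on cells (Cancer cell lines, Homo sapiens) for cytotoxicity, read by sulforhodamine B assay, with a stated time of 48 h; a higher number here means a weaker inhibitor of growth, a lower number a stronger inhibitor of growth:
compound 1 `O=C1N=C(N2N=C(c3ccccc3)CC2c2ccccc2O)S/C1=C1/C(=O)Nc2ccccc21`: 2030 nM
compound 2 `O=C1N=C(N2N=C(c3ccccc3)CC2c2ccccc2O)S/C1=C1/C(=O)Nc2ccc(Br)cc21`: 240 nM
compound 3 `COc1ccc(C2=NN(C3=NC(=O)/C(=C4\C(=O)Nc5ccc(Cl)cc54)S3)C(c3ccc(Cl)cc3)C2)cc1`: 200 nM

Compound 1 gives the highest number of the three; compound 2 lies nearer to it and compound 3 furthest, both beyond the scatter. Within the data shown here, the one single-point step that is known, an 8.5-fold lower number from compound 1 to compound 2 (0.93 log units; beyond the scatter), concerns a substituent on the aromatic ring of the shared core and leaves the saturated ring carbon untouched.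

Compound 4 `CN(C)c1ccc(C2CC(c3ccccc3)=NN2C2=NC(=O)/C(=C3\C(=O)Nc4ccccc43)S2)cc1` differs from compound 1 only there: 4-(dimethylamino)phenyl in place of 2-hydroxyphenyl on a saturated ring carbon. Among the measured compounds shown here, no measured step bears directly on this change. Compound 3, which carries a differently substituted phenyl on that carbon, gives 200 nM, but it also differs from compound 1 at two further places, so nothing about the saturated-ring-carbon group alone can be read from it.

For the measured compounds named here, with no step on record for this position, the number for compound 4 is expected to stay close to that of compound 1, with a wide margin: estimate 1300 nM, range 300 nM to 5000 nM, corresponding to a 1.6-fold lower number from compound 1 to compound 4 (0.19 log units; within the scatter).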

Compound 4, concentration for 50% growth inhibition: 7420 nM
Compound 4: the middle estimate sits 5.7-fold (0.76 log units) below what was measured, and the stated range ends below it.
By their numbers in this assay, from the lowest: compounds 3 and 2 (each within the scatter of the next); then compound 1; then compound 4.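

Among these compounds, the group on the saturated ring carbon matters in this assay: 4-(dimethylamino)phenyl in place of 2-hydroxyphenyl gives a 3.7-fold higher number from compound 1 to compound 4 (0.56 log units; beyond the scatter), the first single-point step at this position and one that runs towards weaker growth inhibition. The change removes the hydrogen-bond donor and adds heavy atoms, and this one step cannot separate those two differences or show which of them, if either, accounts for the shift. No measurement at hand explains the higher number.

Going by these compounds, it remains open whether an unsubstituted phenyl on this carbon, or a methoxy or amino group in place of the hydroxyl, would stand nearer compound 1 or compound 4. Also open, on these data alone, is whether bromo in place of hydrogen, as in an 8.5-fold lower number from compound 1 to compound 2 (0.93 log units; beyond the scatter), would lower the number to a similar extent on compound 4.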